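From a selenium atom to methylsulfanyl on a fused core

A few compounds are considered here, and "the series" means these few. Any claim that something is new, unique, unknown or untested is made for them only; others in the source may bear on it.

The account begins with compound 1 `[SeH]c1nc(NCc2ccccc2)c2cccnc2n1` and its companion compound 2 `[SeH]c1nc(NCc2ccccc2)c2ccccc2n1`. In a functional assay on CCRF-CEM cells (Homo sapiens) for cytotoxicity, read by MTT assay, with a stated time of 72 h (a lower number here means that less compound is tolerated, a higher number that more compound is tolerated), compound 1 reaches only the limit of the assay, > 100000 nM, so no number is known for it. In this assay compound 2 likewise stops at the limit, > 100000 nM. Going by the values given here, both values thus sit at the same point, (the limit of > 100000 nM in this assay, at which 2 of the 2 values shown sit), and no step between the measured compounds can be given; the two values show only that both compounds lie at the limit of the assay.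

Compound 3 `CSc1nc(NCc2ccccc2)c2cccnc2n1` has not yet been measured. It differs from compound 1 in one place: a group of 2 heavy atoms (1 carbon, 1 sulfur; no ring) in place of one selenium atom, on an aromatic carbon, between two ring nitrogen atoms. With compound 1 at the limit, the size of the step cannot be read from the data; the expectation is that compound 3 stays near the limit, the expected step being a number no higher from compound 1 to compound 3 (the limit leaves the size open), within the scatter. For compound 3 the estimated value is 100000 nM, with a range from 30000 nM to 300000 nM.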

Compound 3, concentration lethal to 50% of the cells: > 100000 nM
Compound 3: only a limit was reported; the forecaster's own chance of this, stated with the estimate: 70%; the middle value lies on the limit itself.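

In this assay compound 3 gives > 100000 nM as a limit of the assay and not a number. Going by these compounds alone, no step from compound 1 to compound 3 can be read, and all three compounds share one point: the limit of > 100000 nM in this assay, at which 3 of the 3 values shown sit. The compounds shown leave open what number any of them would reach, and whether methylsulfanyl in place of selenium changes it at all.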